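Phenyl for Methyl at the Ester: Two Matched Pairs

This account rests on a few compounds, and the source may have more. Where it says the series, first, only, none or still open, it means among the compounds named here.

Compound 1 `C=C[C@@](C)(/C=C/c1ccc(O)cc1)CC/C=C/C(=O)OCC` gives > 52000 nM in a functional assay on HepG2 cells (Homo sapiens) for cytotoxicity, with a stated time of 72 h (a lower number here means that less compound is needed, a higher number that more compound is needed for the effect), which is a limit of the assay and not a number.
Compound 2 `C=C[C@@](C)(/C=C/c1ccc(O)cc1)CC/C=C/C(=O)OCc1ccccc1` gives > 52000 nM in this assay, again a limit rather than a number.
Compound 3 `C=C[C@@](C)(/C=C/c1ccc(O)c(/C=C/C(=O)OCC)c1)CCC=C(C)C` gives > 52000 nM in this assay, also a limit.

Compound 1 and compound 2 share a core and differ only by phenyl in place of methyl on a saturated chain carbon bound to an oxygen next to a carbonyl group. The step between them, a step that the two limits leave unreadable from compound 1 to compound 2, cannot be read because both values are limits. Compound 3 carries a different core; how its core differs from that of compound 1 is not broken down here.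

Compound 4 `C=C[C@@](C)(/C=C/c1ccc(O)c(/C=C/C(=O)OCc2ccccc2)c1)CCC=C(C)C` has not been measured yet. It differs from compound 3 by phenyl in place of methyl on a saturated chain carbon bound to an oxygen next to a carbonyl group, and the place of the change is described in the same words as for the change from compound 1 to compound 2, so it is the same change made on a second core.

Among the measured compounds shown here, with every value so far a limit, there is no measured step to lean on. The step from compound 3 to compound 4 is expected to be a step that the limit leaves unreadable from compound 3 to compound 4, because all three values shown sit at the limit of > 52000 nM in this assay, at which 3 of the 3 values shown sit, and the same change on the first core left compound 2 at the same limit as compound 1. Compound 4 is therefore estimated at 80000 nM, with a range from 30000 nM to 300000 nM, most likely reported as a limit again.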

Compound 4, half-maximal effective concentration: > 52000 nM
Compound 4 ended at the assay's limit; the forecaster's own chance of this, stated with the estimate: 85%; the middle value is on the limit's open side.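

Compound 3 and compound 4 both end at a limit of the assay rather than a number, so no size can be read for the change from methyl to phenyl between them: the limit of > 52000 nM in this assay, at which 4 of the 4 values shown sit.

The compounds shown leave open how much of any of them is needed for the effect in this assay, and whether phenyl in place of methyl alters that amount on either core.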